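From Trifluoroethyl to Phenyl on a Carbonyl Carbon

A few compounds are considered here, and "the series" means these few. Any claim that something is new, unique, unknown or untested is made for them only; others in the source may bear on it.

In a physicochemical assay for solubility, at pH 6.8 (on this read-out lower numbers stand for lower solubility and higher numbers for higher solubility), compound 1 `Nc1ccc(CNC(=O)Nc2ccc(CN3C(=O)c4ccccc4C3=O)cc2)cn1` gives only a limit, < 5000 nM. Compound 2 `C[C@H](NC(=O)CC(F)(F)F)c1ccc(NC(=O)[C@H]2C[C@@H]2c2cccnc2)cc1` reads 41000 nM, and compound 3 `C[C@H](NC(=O)C1CCOCC1)c1ccc(NC(=O)[C@H]2C[C@@H]2c2cccnc2)cc1` reads 90000 nM. Compound 2 therefore holds the lower of the two actual numbers, with compound 3 as its nearest neighbour.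

Compound 4 `C[C@H](NC(=O)c1ccccc1)c1ccc(NC(=O)[C@H]2C[C@@H]2c2cccnc2)cc1` departs from compound 2 in one place: phenyl in place of 2,2,2-trifluoroethyl on a carbonyl carbon. This puts phenyl in place of 2,2,2-trifluoroethyl on a carbonyl carbon. Going by the values given here, only one measured step touches that place: a 2.2-fold higher number from compound 2 to compound 3 (0.34 log units; beyond the scatter), a modest change that brings in oxan-4-yl. Phenyl is instead one six-membered aromatic ring of carbon only, so that step is a guide to size more than direction. A similarly modest move toward a lower number is expected, though this direction rests on thin evidence. The expected change is a 2.1-fold lower number from compound 2 to compound 4 (0.31 log units; beyond the scatter). For compound 4, the estimated value is 20000 nM, with an expected range from 7000 nM to 50000 nM.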

Compound 4, solubility: < 4000 nM
Compound 4 ended at the assay's limit (the forecaster's own chance of this, stated with the estimate: 10%); middle value at least 5.0-fold (0.69 log units) from the limit.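

In this assay, phenyl in place of 2,2,2-trifluoroethyl on a carbonyl carbon gives an at least 10-fold lower number from compound 2 to compound 4 (1.01 log units; beyond the scatter), and phenyl in place of oxan-4-yl gives an at least 22-fold lower number from compound 3 to compound 4 (1.35 log units; beyond the scatter), so the group at this place can shift the read-out by a large step and not only by the modest one seen earlier. The value of compound 4 is a limit and not a number: the limit of < 4000 nM in this assay, at which 1 of the 4 values shown sits. Of the three groups shown on this carbonyl carbon, only phenyl, with its six-membered aromatic ring of carbon only, takes the read-out to a limit.

As far as these compounds go, the true size of both steps stays open, as does whether the large shift goes with any aromatic ring or with phenyl alone. A pyridine ring at this place, or a phenyl carrying a carboxylic acid or an amine, would help to separate these possibilities.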